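The source may report more compounds than this note shows. Statements on the series, on what has been measured and on what is new or still open speak of the compounds shown alone.

Two measured compounds share the core and differ only in the chlorine pattern on the terminal phenyl group. In a functional assay on HT-29 cells (Homo sapiens) (on this read-out higher numbers stand for weaker inhibition of growth and lower numbers for stronger inhibition of growth), compound 1 `O=S(=O)(/C=C/c1ccc(Cl)c(Cl)c1)Cc1ccc(Nc2ncnc3ccccc23)cc1` gives 11000 nM and compound 2 `O=S(=O)(/C=C/c1ccc(Cl)cc1Cl)Cc1ccc(Nc2ncnc3ccccc23)cc1` gives 24000 nM. Compound 2 therefore holds the higher of the two numbers, meaning the weaker growth inhibition of this pair. Within the data shown here, the only measured step is a 2.2-fold higher number from compound 1 to compound 2 (0.34 log units; beyond the scatter), which is modest and beyond the scatter.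

Compound 3 `O=S(=O)(/C=C/c1ccc(Cl)cc1Cl)Cc1ccc(Nc2ncnc3cc(Cl)ccc23)cc1` keeps the dichlorophenyl group of compound 2 and changes the other side of the molecule: chloro in place of hydrogen on an aromatic carbon. The new chloro sits on a six-membered aromatic ring of carbon only, part of a fused or bridged system of two rings. The measured step changes a different ring, so it offers only a rough gauge of size and no direction. Among the measured compounds shown here, no measured pair tests substitution at this carbon.

A small step in this assay is therefore expected, not beyond the scatter, with a slight lean toward a lower number. The expected change is a 1.6-fold lower number from compound 2 to compound 3 (0.20 log units; within the scatter). For compound 3 the estimated value is 15000 nM, with an expected range of 4000 nM to 50000 nM.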

Compound 3, concentration for 50% growth inhibition: 59000 nM
Beside the measured number, compound 3's estimate is 3.9-fold (0.59 log units) below it; measured number above the stated range.
By their numbers in this assay, from the lowest: compound 1; then compound 2; then compound 3.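

In this assay, chloro in place of hydrogen on an aromatic carbon of the six-membered aromatic ring of carbon only, meta to a fused ring and para to a fused ring, gives a 2.5-fold higher number from compound 2 to compound 3 (0.39 log units; beyond the scatter), so this carbon responds to the change and the direction is toward weaker inhibition of growth. Among these compounds, this is the first measured step on this side of the molecule, and, like a 2.2-fold higher number from compound 1 to compound 2 (0.34 log units; beyond the scatter) on the dichlorophenyl group, it is modest and beyond the scatter, so both ends of the series now show a measurable response in this assay. No measurement on hand accounts for the direction of this step.

As far as these compounds go, with only chloro read at this carbon, it remains open whether the weaker inhibition of growth is specific to chloro or would also appear with fluoro, a methoxy group or an amine there. Also open, from the compounds shown here alone, is whether the step carries over to the 3,4-dichlorophenyl group of compound 1, as chloro at this carbon is read here only with the 2,4-dichlorophenyl group.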